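The source may report more compounds than this note shows. Statements on the series, on what has been measured and on what is new or still open speak of the compounds shown alone.

Working notes on the series. Compound 3 `CCCc1nc(C)c2c(C)nnc(O)n12` is the reference point; compound 1 `CCCc1nc(C)c2c(C(C)C)nnc(O)n12` and compound 2 `CCCCc1nnc(O)n2c(CCC)nc(C)c12` carry larger groups on the same core. Among the compounds with values here, in a functional assay for inhibition, with Homo sapiens as the target (a lower number here means a stronger inhibitor, a higher number a weaker inhibitor), compound 3 gives 14000 nM, the only plain number in the set. For compound 1 the result is a limit of the assay, > 48000 nM. For compound 2 the result is likewise a limit, > 48000 nM. Compound 4 `CCCc1nc(C)c2c(CC)nnc(O)n12` differs from compound 3 by methyl in place of hydrogen on a saturated chain carbon bound to an aromatic carbon, which cut one bond further out reads methyl to ethyl.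

Within the data shown here, two measured steps bear on this change: an at least 3.4-fold lower number from compound 1 to compound 3 (0.53 log units; beyond the scatter) and an at least 3.4-fold lower number from compound 2 to compound 3 (0.53 log units; beyond the scatter). Both replace a larger group with a smaller one and both lower the number. The step to compound 4 moves part of the way back toward the larger groups, so a rise in this assay is expected, smaller than either measured step. For compound 4 the expected step is a 2.0-fold higher number from compound 3 to compound 4 (0.30 log units; within the scatter). With two of three results sitting at the limit of > 48000 nM in this assay, at which 2 of the 3 values shown sit, a limit rather than a number remains possible. For compound 4 the estimate in this assay is 28000 nM, between 10000 nM and 80000 nM.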

Compound 4, half-maximal inhibitory concentration: 15600 nM
For compound 4 the middle estimate is 1.8-fold (0.25 log units) above the measured one, and the stated range covers the measured number.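

In this assay, within the data shown here, the change gives a 1.1-fold higher number from compound 3 to compound 4 (0.05 log units; within the scatter), so methyl to ethyl on this aromatic carbon shows no readable difference, something the earlier compounds could not show. Compound 4 keeps the separation from the larger groups that compound 3 has, with an at least 3.0-fold lower number from compound 2 to compound 4 (0.48 log units; beyond the scatter) and an at least 3.0-fold lower number from compound 1 to compound 4 (0.48 log units; beyond the scatter), so among the compounds shown the rise in the number lies beyond ethyl, at butyl and isopropyl. Both of these steps rest on a limit and give only a bound on their size: the limit of > 48000 nM in this assay, at which 2 of the 4 values shown sit.

From the compounds shown here alone, whether a propyl chain in this place would read with compound 3 and compound 4, or with compound 1 and compound 2, stays open. Also open, going by these compounds, is how an amine or a carboxylic acid on that chain would read in this assay.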